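Estimating compound 4 from one measured step

The compounds below may be only part of what the source reports. "The series", "measured", "known", "first", "only" and "open" are said of these compounds alone.

Compound 1 `COc1cc(/C=C/C(=O)/C=C/c2sccc2C)cc(OC)c1OC` – 9310 nM
Compound 2 `COc1ccc(/C=C/C(=O)C(=Cc2cc(OC)c(OC)c(OC)c2)C(=O)/C=C/c2ccc(OC)c(OC)c2)cc1OC` – 230 nM
Compound 3 `COc1cc(C=C(C(=O)/C=C/c2ccc(OC)c(OC)c2)C(=O)/C=C/c2ccc(OC)c(OC)c2)ccc1O` – 530 nM

All three values come from a functional assay on A549 cells (Homo sapiens) for inhibition, read by sulforhodamine B assay, with a stated time of 48 h; a higher number here means a weaker inhibitor of growth, a lower number a stronger inhibitor of growth. Compound 3, at 530 nM, holds the middle place among them. Compound 2 has the lower number, 230 nM, and compound 1 has the higher number, 9310 nM.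

The next compound to be tested in this assay is compound 4 `COc1ccc(/C=C/C(=O)C(=Cc2ccc(N(C)C)cc2)C(=O)/C=C/c2ccc(OC)c(OC)c2)cc1OC`. It differs from compound 3 by one exchange: 4-(dimethylamino)phenyl in place of 4-hydroxy-3-methoxyphenyl on a double-bonded chain carbon bound to a double-bonded chain carbon. Within the data shown here, the 4-(dimethylamino)phenyl group appears in none of the measured compounds, so its effect has not been observed directly.

Among the measured compounds shown here, only one measured step bears on this exchange. It involves the same place, on a double-bonded chain carbon bound to a double-bonded chain carbon, and it is modest: a 2.3-fold higher number from compound 2 to compound 3 (0.36 log units; beyond the scatter). That step gives a rough idea of how far a change at this place has moved the number, but it does not fix a direction for the new group. A step of no more than similar size is therefore expected, most likely none beyond the scatter, with a slight lean toward a lower number. The expected step is a 1.2-fold lower number from compound 3 to compound 4 (0.07 log units; within the scatter). For compound 4 the estimated value is 450 nM, with an expected range of 150 nM to 1400 nM.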

Compound 4, concentration for 50% growth inhibition: 2620 nM
The estimate for compound 4 lay 5.8-fold (0.77 log units) below the measured number; measured number outside the range, above it.
By their numbers in this assay, from the lowest: compound 2; then compound 3; then compound 4; then compound 1.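

In this assay, this place on a double-bonded chain carbon bound to a double-bonded chain carbon proved sensitive to the group it carries: 4-(dimethylamino)phenyl in place of 4-hydroxy-3-methoxyphenyl gave a 4.9-fold higher number from compound 3 to compound 4 (0.69 log units; beyond the scatter), and the same group in place of 3,4,5-trimethoxyphenyl gave an 11-fold higher number from compound 2 to compound 4 (1.06 log units; beyond the scatter). The three groups now fall in one order at this place, from the lowest number to the highest: 3,4,5-trimethoxyphenyl, 4-hydroxy-3-methoxyphenyl and 4-(dimethylamino)phenyl, so the two groups with oxygen on the ring both stand below the one with nitrogen, a pattern that rests on compound 2, compound 3 and compound 4 alone. No measurement available here accounts for this order.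

The compounds shown cannot separate the effect of adding the dimethylamino group from that of removing the methoxy groups, a question that a plain phenyl, a 4-methoxyphenyl or a 4-aminophenyl group at this place would help to settle. As far as these compounds go, it also remains open whether a 4-(diethylamino)phenyl group would fall close to compound 4 or move the number further.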